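Urea series: tert-butyl for piperidinyl on the indane carbocycle

A few compounds are considered here, and "the series" means these few. Any claim that something is new, unique, unknown or untested is made for them only; others in the source may bear on it.

Compound 1 `O=C(Nc1cccc2[nH]ncc12)NC1CCc2c1cccc2N1CCCCC1` is the stronger of the two measured compounds. In an assay on isolated protein for inhibition of transient receptor potential cation channel subfamily V member 1 (Homo sapiens), read by calcium flux (on this read-out higher numbers stand for weaker inhibition and lower numbers for stronger inhibition), compound 1 gives 10 nM, the lowest number in the set. Its nearest neighbour, compound 2 `O=C(Nc1cccc2[nH]ncc12)NC1CCc2ncccc21`, gives 5820 nM in this assay, a gap far beyond the usual scatter; the two structures differ in more than one place, so only the two values themselves are compared here.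

Compound 3 `CC(C)(C)c1cccc2c1CCC2NC(=O)Nc1cccc2[nH]ncc12` is not yet measured. It differs from compound 1 by tert-butyl in place of piperidin-1-yl on an aromatic carbon. Among the compounds with values here, no measured pair isolates this change, so the expected step rests on compound 1 alone, at 10 nM in this assay. The step from compound 1 to compound 3 is expected to be small, a 1.5-fold higher number from compound 1 to compound 3 (0.18 log units; within the scatter), toward a slightly higher number but hardly beyond the scatter. Compound 3 is therefore estimated at 15 nM, with a range from 4 nM to 60 nM.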

Compound 3, half-maximal inhibitory concentration: 14 nM
Compound 3: the middle estimate sits 1.1-fold (0.03 log units) above what was measured, and the stated range covers the measured number.
By their numbers in this assay, from the lowest: compounds 1 and 3 (each within the scatter of the next); then compound 2.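

In this assay, tert-butyl in place of piperidin-1-yl on this aromatic carbon gives a 1.4-fold higher number from compound 1 to compound 3 (0.15 log units; within the scatter) and so leaves the two values indistinguishable. For this pair, the six-membered non-aromatic ring, its hetero atom and its hydrogen-bond acceptor are therefore not required for a value in this range, and an all-carbon group with no ring serves equally well. No available evidence bears on why the two groups read alike.

From the compounds shown here alone, it remains open whether the same aromatic carbon accepts a much smaller group such as methyl, or a charged one such as a carboxylic acid. A single pair also cannot show whether other amines, such as morpholin-4-yl or dimethylamino, would read like piperidin-1-yl and tert-butyl.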